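The source may hold more compounds than are shown below. What is called first, only, known or untested is meant among the compounds shown, and "the series" means these compounds.

Compound 1 `O=C1/C(=C/c2ccccc2F)CN(S(=O)(=O)c2ccc(Cl)cc2)C/C1=C\c1ccccc1F` and compound 2 `O=C1/C(=C/c2ccccc2F)CN(S(=O)(=O)c2ccc(Br)cc2)C/C1=C\c1ccccc1F` share one core; compound 3 `O=C1/C(=C/c2cccc(F)c2)CN(S(=O)(=O)c2ccc(Cl)cc2)C/C1=C\c1cccc(F)c1` and compound 4 `O=C1/C(=C/c2cccc(F)c2)CN(S(=O)(=O)c2ccc(Br)cc2)C/C1=C\c1cccc(F)c1` share another, and the difference between the two cores is not broken down here. In a functional assay on HepG2 cells (Homo sapiens) for cytotoxicity, read by MTT assay, with a stated time of 24 h (a lower number here means a stronger inhibitor, a higher number a weaker inhibitor), compound 1 gives 10900 nM and compound 2 gives 13700 nM. The structural change between them is bromo in place of chloro on an aromatic carbon, and the step it made was a 1.3-fold higher number from compound 1 to compound 2 (0.10 log units; within the scatter). In this assay compound 3 gives 13100 nM. Compound 4 carries the same change against compound 3, namely (bromo in place of chloro on an aromatic carbon), at a place described in identical words. On the strength of a 1.3-fold higher number from compound 1 to compound 2 (0.10 log units; within the scatter), the expected step is a 1.2-fold higher number from compound 3 to compound 4 (0.09 log units; within the scatter). Compound 4 is therefore estimated at 16000 nM, with a likely range from 8000 nM to 32000 nM.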

Compound 4, half-maximal inhibitory concentration: 7700 nM
For compound 4 the middle estimate is 2.1-fold (0.32 log units) above the measured one; measured number outside the range, below it.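

Bromo in place of chloro gives a 1.7-fold lower number from compound 3 to compound 4 (0.23 log units; within the scatter) in this assay. Set beside the step on the other core, the two cannot be told apart: the same change on two cores in this assay, a 1.3-fold higher number (0.10 log units; within the scatter) from compound 1 to compound 2 and a 1.7-fold lower number (0.23 log units; within the scatter) from compound 3 to compound 4, 2.1-fold (0.33 log units) apart, within the scatter of two such steps. For the compounds shown here, the steps point in opposite directions, but that should not be read as a real difference between the cores; the result shows only that neither core gives a clear effect from this swap, and it does not show that the same would hold on any other core.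

The compounds shown leave open what a quite different group in place of the chloro would do, such as an amine, a carboxylic acid or a nitrile.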